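The source may report more compounds than this note shows. Statements on the series, on what has been measured and on what is new or still open speak of the compounds shown alone.

Compound 2 `COc1cc2c(Oc3ccc(NC(=O)c4nnc(-c5ccc(F)cc5)o4)cc3)ccnc2cc1OCCCN1CCC(C)CC1` carries the highest of the two numbers in a functional assay on HT-29 cells (Homo sapiens) for antiproliferative activity, read by MTT assay, with a stated time of 72 h (on this read-out lower numbers stand for stronger inhibition and higher numbers for weaker inhibition), giving 7890 nM; compound 1 `COc1cc2c(Oc3ccc(NC(=O)c4nc(-c5ccc(F)cc5)no4)cc3)ccnc2cc1OCCCN1CCC(C)CC1` gives 6380 nM, and the step of a 1.2-fold higher number from compound 1 to compound 2 (0.09 log units; within the scatter) sits within the scatter. Compound 3 `COc1cc2c(Oc3ccc(NC(=O)c4ncc(-c5ccc(F)cc5)o4)cc3)ccnc2cc1OCCCN1CCC(C)CC1` differs from compound 2 in one place: 5-(4-fluorophenyl)-1,3-oxazol-2-yl in place of 5-(4-fluorophenyl)-1,3,4-oxadiazol-2-yl on a carbonyl carbon. Among the measured compounds shown here, the one measured step touching this ring exchanged one five-membered aromatic ring with 3 hetero atoms for another and barely moved the number, so for the ring with 2 hetero atoms the expected step in this assay is a 1.1-fold lower number from compound 2 to compound 3 (0.05 log units; within the scatter), no larger than the scatter. Compound 3 is estimated at 7000 nM, within a range of 2500 nM to 20000 nM.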

Compound 3, half-maximal inhibitory concentration: 1890 nM
For compound 3 the middle estimate is 3.7-fold (0.57 log units) above the measured one; the whole stated range lies above it.
By their numbers in this assay, from the lowest: compound 3; then compounds 1 and 2 (each within the scatter of the next).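

In this assay this place on a carbonyl carbon proves sensitive to the ring after all: 5-(4-fluorophenyl)-1,3-oxazol-2-yl gives a 4.2-fold lower number from compound 2 to compound 3 (0.62 log units; beyond the scatter) and a 3.4-fold lower number from compound 1 to compound 3 (0.53 log units; beyond the scatter), whereas the two oxadiazole rings stay within the scatter of each other. The ring with 2 hetero atoms is thus the only one of the three set apart by its number. Nothing available accounts for this gain.

As far as these compounds go, whether a 1,3-thiazol-2-yl or imidazol-2-yl ring in this place would go further remains open. So does whether the gain holds with 4-methoxyphenyl in place of 4-fluorophenyl.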